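The source may report more compounds than this note shows. Statements on the series, on what has been measured and on what is new or still open speak of the compounds shown alone.

Two small hydroxamic acids have been measured in an assay on isolated protein for inhibition of tyrosine-protein kinase CSK (Homo sapiens), tested at 25 uM, in the presence of a further agent that is not named here; on this read-out higher numbers stand for more inhibition at the one concentration tested (going by the name of the read-out) and lower numbers for less inhibition. Compound 1 `CCCC(N)C(=O)NO` gives 40% in this assay. Compound 2 `NCCC(=O)NO` gives 7% in this assay. Compound 2 thus stands at the lower of the two numbers, and compound 1 lies above it by a gap that is beyond the usual scatter of repeated measurements of this kind. For the measured compounds named here, no step between two measured compounds can be read off here, since compound 1 and compound 2 differ in more than one place. The next compound, compound 3 `NCC(=O)NO`, has not yet been measured. It differs from compound 2 in one place: amino in place of aminomethyl on a saturated chain carbon bound to a carbonyl carbon. Going by the values given here, with only one measured neighbour and a starting value already near the bottom of the scale, compound 1 and compound 2 give no firm lesson about what this shortening will do. The expected step, a number 2 percentage points lower from compound 2 to compound 3 (within the scatter), is small, downward if anything, and not beyond the scatter. Compound 3 is therefore expected to give about 5% in this assay, with a likely range from 0% to 20%.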

Compound 3, a percentage reported as inhibition, at one concentration (the size of the read-out at that concentration, not a potency): 45%
The estimate for compound 3 lay 40 percentage points below the measured number; measured number above the stated range.
By their numbers in this assay, from the lowest: compound 2; then compounds 1 and 3 (each within the scatter of the next).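

In this assay, the amine's place on the chain matters far more than the earlier pair could show: amino in place of aminomethyl, on a saturated chain carbon bound to a carbonyl carbon, gives a number 38 percentage points higher from compound 2 to compound 3 (beyond the scatter) and is a large change for so small an edit. The other change, hydrogen in place of propyl on a saturated chain carbon bound to an amine nitrogen and a carbonyl carbon, gives a number 5 percentage points higher from compound 1 to compound 3 (within the scatter) and so leaves the number unchanged within the scatter, which means this assay does not separate the propyl compound from the unsubstituted one. Nothing measured here explains either result.

From the compounds shown here alone, what remains open is whether groups of other sizes on that same carbon, such as methyl or a longer chain than propyl, would also leave the number in place. Going by these compounds, it is also open whether a longer chain carrying the amine would stay as low as compound 2, and whether a carboxylic acid could stand in for the hydroxamic acid at all.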